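Moving the trifluoromethyl group on the phenoxy ring

A few compounds are considered here, and "the series" means these few. Any claim that something is new, unique, unknown or untested is made for them only; others in the source may bear on it.

Compound 1, `COc1cc(/C=N/NC(=O)c2ccc(O)c(Cl)c2)cc(OC)c1OCc1ccc(C(F)(F)F)cc1`: 140 nM
Compound 2, `COc1cc(/C=N/NC(=O)c2ccc(O)c(Cl)c2)ccc1OCc1cccc(C(F)(F)F)c1`: 404 nM
Compound 3, `O=C(N/N=C/c1cccc(COc2cccc(C(F)(F)F)c2)c1)c1ccc(O)c(Cl)c1`: 274 nM

These three compounds were measured in an in vitro assay on HEK293f cells for displacement of a labelled ligand from pituitary adenylate cyclase-activating polypeptide type I receptor (Homo sapiens); a higher number here means a weaker inhibitor, a lower number a stronger inhibitor. On the numbers shown, compound 3 sits in the middle of the three, and both the gap to compound 2 and the gap to compound 1 are within the usual scatter of this assay. Compound 4, `O=C(N/N=C/c1cccc(COc2ccc(C(F)(F)F)cc2)c1)c1ccc(O)c(Cl)c1`, has not been measured. It differs from compound 3 in one place: 4-(trifluoromethyl)phenyl in place of 3-(trifluoromethyl)phenyl on an oxygen on a saturated carbon. Among the measured compounds shown here, no measured pair shows this change alone, and compounds 1 and 2 differ from each other in more than one place, so no step can be read from them. The step from compound 3 to compound 4 is therefore expected to stay within the scatter, a 1.1-fold lower number from compound 3 to compound 4 (0.04 log units; within the scatter). Compound 4 is estimated at 250 nM, with a range from 100 nM to 650 nM.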

Compound 4, inhibition constant: 241 nM
The estimate for compound 4 lay 1.0-fold (0.02 log units) above the measured number; measured number inside the range.
By their numbers in this assay, from the lowest: compounds 1, 4, 3 and 2 (each within the scatter of the next, the first and the last beyond it).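

In this assay, among the compounds shown here, this is the first pair to differ in one place, and it gives a 1.1-fold lower number from compound 3 to compound 4 (0.06 log units; within the scatter). On an oxygen on a saturated carbon, 4-(trifluoromethyl)phenyl and 3-(trifluoromethyl)phenyl therefore cannot be told apart in this read-out, so the same atoms joined differently leave the number unresolved from its neighbour. No accompanying measurement offers an explanation for this result. Still open, on these data alone, is whether a nitrile or a methyl group, put in place of the trifluoromethyl, would give a similar number. Also open, as far as these compounds go, is what an unsubstituted phenyl would give at this position.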